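Swapping the dimethoxypyrimidin-4-yl group for a dioxo ring

A few compounds are considered here, and "the series" means these few. Any claim that something is new, unique, unknown or untested is made for them only; others in the source may bear on it.

compound 1 `COc1cc(CC(O)(COCc2ccccc2)COCc2ccccc2)nc(OC)n1`: > 100000 nM
compound 2 `COc1nc(CC(O)(COCc2ccccc2)COCc2ccccc2)c(C)c(OC)n1`: 3700 nM

In a functional assay on HeLa cells (Homo sapiens) for antiproliferative activity, read by MTT assay, with a stated time of 72 h (on this read-out lower numbers stand for stronger inhibition and higher numbers for weaker inhibition), compound 1 gives > 100000 nM, which is a limit of the assay and not a number. Compound 1 therefore stands only at the limit of > 100000 nM in this assay, at which 1 of the 2 values shown sits, with no measured number of its own. Compound 2 gives 3700 nM in this assay. For the measured compounds named here, the single measured step, an at least 27-fold lower number from compound 1 to compound 2 (1.43 log units; beyond the scatter), concerns a methyl in place of hydrogen on an aromatic carbon and leaves the headgroup otherwise untouched, so it does not speak to the change toward compound 3.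

Compound 3 `O=c1cc(CC(O)(COCc2ccccc2)COCc2ccccc2)[nH]c(=O)[nH]1` differs from compound 1 by a group of 8 heavy atoms (4 carbon, 2 nitrogen, 2 oxygen; one six-membered aromatic ring with 2 hetero atoms) in place of a group of 10 heavy atoms (6 carbon, 2 nitrogen, 2 oxygen; one six-membered aromatic ring with 2 hetero atoms), on a saturated chain carbon, two bonds along the chain from an oxygen on a saturated carbon. No measured step bears on this exchange, and the starting point is itself only a limit, so no direction can be read from the data shown. The step that the limit leaves unreadable from compound 1 to compound 3 is expected to stay at or near the limit, with the value remaining unresolved. Compound 3 is estimated at 150000 nM in this assay, with a range from 30000 nM to 600000 nM, and most likely reported again only as a limit.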

Compound 3, half-maximal inhibitory concentration: > 100000 nM
Compound 3 gave a limit, no number (the forecaster's own chance of this, stated with the estimate: 75%); the middle value is on the limit's open side.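

In this assay compound 3 gives > 100000 nM, a limit of the assay and not a number. Compound 1 also rests on a limit, so no step from compound 1 to compound 3 can be read: the limit of > 100000 nM in this assay, at which 2 of the 3 values shown sit.

The compounds shown leave open whether the group in compound 3 and the 2,6-dimethoxypyrimidin-4-yl group of compound 1 differ at all in this assay.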